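The source may report more compounds than this note shows. Statements on the series, on what has been measured and on what is new or still open speak of the compounds shown alone.

Measured so far:
Compound 1 `Cc1cc(C(=O)O)c(C)n1CC1CC1` gives 12700 nM in an assay on cells for inhibition of Palmitoleoyl-protein carboxylesterase NOTUM variant C330S (Homo sapiens), read by fluorescence, with a stated time of 40 min; on this read-out higher numbers stand for weaker inhibition and lower numbers for stronger inhibition.
Compound 2 `Cc1cc(C(=O)O)c(C)n1-c1cccc(F)c1` gives 1500 nM in this assay.

Both compounds share a core that carries a carboxylic acid and two methyl groups, and they differ in what hangs from the ring nitrogen. Of the two numbers available, compound 2 has the lower one and so the stronger inhibition; compound 1 sits well beyond the usual scatter from it, with a clearly higher number.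

Compound 3 `Cc1cc(C(=O)O)c(C)n1-c1cccc(Cl)c1` has not yet been measured in this assay. It keeps the aromatic ring of compound 2 and changes a single atom on it: chloro in place of fluoro on an aromatic carbon. The substituent sits on an aromatic carbon of a six-membered aromatic ring of carbon only, meta to a large group. Among the measured compounds shown here, no pair of measured compounds shows what a fluoro-to-chloro swap does on this core, so the direction has to be guessed. A modest gain, with the step from compound 2 to compound 3 expected to be a 1.9-fold lower number from compound 2 to compound 3 (0.27 log units; within the scatter), seems plausible but might still fall inside the scatter. Compound 3 is therefore estimated at 800 nM, with a likely range from 250 nM to 2500 nM.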

Compound 3, half-maximal inhibitory concentration: 430 nM
For compound 3 the middle estimate is 1.9-fold (0.27 log units) above the measured one, within the range that was stated.
By their numbers in this assay, from the lowest: compound 3; then compound 2; then compound 1.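

Exchanging a single atom, chloro in place of fluoro on an aromatic carbon meta to a large group, gives a 3.5-fold lower number from compound 2 to compound 3 (0.54 log units; beyond the scatter) in this assay and so marks this place on the aromatic ring as one where the choice of substituent matters. Among the compounds shown here, this is the first comparison in which only one place differs, and it shows that a modest but real change in the number can arise even though the heavy-atom count and the counts of hydrogen-bond donors and acceptors stay the same. Nothing measured here accounts for why chloro gives the lower number than fluoro.

On these data alone, with only fluoro and chloro at this place, two points cannot show a trend, so it remains open whether a bromo, a methyl, a methoxy or a nitrile there would lower the number further or raise it again. As far as these compounds go, it is also open how much the aromatic ring's substituent contributes at all compared with a plain unsubstituted ring, and whether the carboxylic acid of the shared core could give way to an amide.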